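The source may report more compounds than this note shows. Statements on the series, on what has been measured and on what is new or still open speak of the compounds shown alone.

Measured compounds in an ADME assay on FSCLL cells (Homo sapiens) for cytotoxicity, read by MTT assay, with a stated time of 24 h; on this read-out higher numbers stand for lower toxicity in this test and lower numbers for higher toxicity in this test:

- compound 1 `CC(C)C[C@H](NC(=O)[C@@H](N)C(C)(C)C)B(O)O`: 710 nM
- compound 2 `CC(C)C[C@H](NC(=O)[C@@H](N)CO)B(O)O`: 1700 nM
- compound 3 `CNCC(=O)N[C@@H](CC(C)C)B(O)O`: 160 nM

Compound 1 stands second highest of the three numbers in this assay; its nearest neighbour is compound 2, and the step between them is a 2.4-fold higher number from compound 1 to compound 2 (0.38 log units; beyond the scatter). The furthest number is that of compound 3, which lies well below compound 1. The step of an 11-fold lower number from compound 2 to compound 3 (1.03 log units; beyond the scatter) changes a different part of the molecule and does not bear on the present question.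

Compound 4 `CCCC[C@H](N)C(=O)N[C@@H](CC(C)C)B(O)O` is not yet measured in this assay. It differs from compound 1 in one place: butyl in place of tert-butyl on a saturated chain carbon bound to an amine nitrogen and a carbonyl carbon. The two have the same atoms, joined differently. Within the data shown here, the only measured step at this place, from compound 1 to compound 2, was a modest rise in the number, and it brought in a hydrogen-bond donor and acceptor that the present change does not. Among the measured compounds shown here, no measured pair shows a change of this exact kind. The step of a 1.1-fold higher number from compound 1 to compound 4 (0.05 log units; within the scatter) is therefore expected to fall within the scatter, with no clear direction. Compound 4 is estimated at 800 nM, with a range from 350 nM to 1800 nM.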

Compound 4, half-maximal cytotoxic concentration: 950 nM
The estimate for compound 4 lay 1.2-fold (0.07 log units) below the measured number; the range from low to high includes it.
By their numbers in this assay, from the lowest: compound 3; then compounds 1, 4 and 2 (each within the scatter of the next, the first and the last beyond it).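

In this assay, butyl and tert-butyl on this saturated chain carbon bound to an amine nitrogen and a carbonyl carbon are not told apart: a 1.3-fold higher number from compound 1 to compound 4 (0.13 log units; within the scatter). Among these compounds, compound 4 is also not separated from the hydroxymethyl compound, with a 1.8-fold lower number from compound 2 to compound 4 (0.25 log units; within the scatter), while a 2.4-fold higher number from compound 1 to compound 2 (0.38 log units; beyond the scatter) remains the only step at this place beyond the scatter, so that single step cannot be read as a rule for the hydroxy group. Nothing available here gives a reason for any of these steps.

On these data alone, whether a longer chain such as octyl, a carboxylic acid or a phenyl ring at this place would move the number beyond the scatter stays open. Also open, as far as these compounds go, is whether an amine at the end of the butyl chain would separate from compound 4.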